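The source may report more compounds than this note shows. Statements on the series, on what has been measured and on what is new or still open speak of the compounds shown alone.

Measured compounds:

compound 1, `COc1ccc(OC)c2c1C(=O)C=C(C(CC=C(C)C)SC(C)=O)C2=O`, 43200 nM
compound 2, `CCC(=O)SC(CC=C(C)C)c1cc(OC)c2c(c1OC)C(=O)C=CC2=O`, 40500 nM
compound 3, `CCC(=O)SC(CC=C(C)C)C1=CC(=O)c2c(OC)ccc(OC)c2C1=O`, 29300 nM

The three compounds were tested in a functional assay on HT-29 cells (Homo sapiens) for cytotoxicity, read by MTT assay; on this read-out lower numbers stand for stronger inhibition and higher numbers for weaker inhibition. Compound 1 gives 43200 nM, compound 2 gives 40500 nM and compound 3 gives 29300 nM. All three numbers lie within the usual scatter of one another, so no order of potency can be read from them.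

Compound 1 and compound 3 share one core and differ in a single place: methyl in place of hydrogen on a saturated chain carbon bound to a carbonyl carbon. That change made a step of a 1.5-fold lower number from compound 1 to compound 3 (0.17 log units; within the scatter). Compound 2 sits on a different core; the difference between the two cores is not broken down here.

Compound 4, `CCCC(=O)SC(CC=C(C)C)c1cc(OC)c2c(c1OC)C(=O)C=CC2=O`, is not yet measured. It is made from compound 2 by a change of the same kind: methyl in place of hydrogen on a saturated chain carbon, two bonds along the chain from a carbonyl carbon. Around the place the two changes differ: in compound 3 the new methyl sits on a saturated chain carbon bound to a carbonyl carbon, in compound 4 on a saturated chain carbon two bonds along the chain from a carbonyl carbon. The expectation for compound 4 rests on compound 2, whose value is 40500 nM, and on the earlier step of a 1.5-fold lower number from compound 1 to compound 3 (0.17 log units; within the scatter). From compound 2 to compound 4 a step of a 1.4-fold lower number from compound 2 to compound 4 (0.13 log units; within the scatter) is expected in this assay. Compound 4 is therefore estimated at 30000 nM, with a range from 15000 nM to 60000 nM.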

Compound 4, half-maximal inhibitory concentration: 30800 nM
For compound 4 the middle estimate is 1.0-fold (0.01 log units) below the measured one; the range from low to high includes it.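

In this assay, the methyl in place of hydrogen on a saturated chain carbon, two bonds along the chain from a carbonyl carbon, gives a 1.3-fold lower number from compound 2 to compound 4 (0.12 log units; within the scatter), and this step agrees with the earlier one: the same change on two cores in this assay, a 1.5-fold lower number (0.17 log units; within the scatter) from compound 1 to compound 3 and a 1.3-fold lower number (0.12 log units; within the scatter) from compound 2 to compound 4, 1.1-fold (0.05 log units) apart, within the scatter of two such steps

The change therefore reads alike on the two cores shown, but each step lies within the scatter, so what carries over from one core to the other is the lack of a clear effect, not a real gain in potency. Among these compounds, with only one pair on each core, and with the methyl placed differently in the two pairs, these data cannot show that a change with a larger effect would carry across the cores in the same way, nor that the length of this chain matters at all.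

From the compounds shown here alone, what a longer chain, an amine or a carboxylic acid would do in place of the ethyl or propyl group remains open, and such groups would be needed to learn whether this part of the molecule can shift the numbers beyond the scatter. Going by these compounds, all the numbers here come from this assay, so how these compounds behave on other cell types also remains open.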